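The source may hold more compounds than are shown below. What is called first, only, known or untested is meant among the compounds shown, and "the series" means these compounds.

Compound 3 `Cn1c(-c2ccc(Cl)cc2)cnc1NC(=O)c1ncc[nH]1` sits at the floor of the measurements shown. In an ADME assay on microsomes from liver (Homo sapiens) for metabolic stability (a higher number here means faster removal of the compound, a lower number slower removal), compound 3 gives < 7 uL/min, which is a limit of the assay rather than a number. Compound 1 `COc1ccc(-c2cnc(NC(=O)c3ncc[nH]3)n2C)cc1` in this assay gives < 7 uL/min, likewise a limit. The step that the two limits leave unreadable from compound 1 to compound 3 therefore cannot be sized, because the limit of < 7 uL/min in this assay, at which 2 of the 3 values shown sit, hides both ends. Compound 2 `O=C(Nc1ncc(-c2ccccc2)o1)c1ccc(F)cc1`, built on a different core, gives 90 uL/min in this assay. Compound 4 `Cn1c(-c2ccccc2)cnc1NC(=O)c1ncc[nH]1` differs from compound 3 by hydrogen in place of chloro on an aromatic carbon. No measured step bears directly on this change, and the one step shown is unreadable. Compound 4 is expected to give 8 uL/min, with a range from 4 uL/min to 20 uL/min. The step of an at least 1.1-fold higher number from compound 3 to compound 4 (0.05 log units; that floor lies within the scatter) is thus expected to stay within the scatter.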

Compound 4, intrinsic clearance in a liver preparation (reported as CLH), per the amount of preparation that the assay uses: 20 uL/min
Estimate against measurement, compound 4: 2.5-fold (0.40 log units) below, and the stated range covers the measured number.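

In this assay, the position para to a large group now gives a readable step: the change from 4-chlorophenyl to phenyl gives an at least 2.8-fold higher number from compound 3 to compound 4 (0.45 log units; beyond the scatter). Hydrogen in place of methoxy gives an at least 2.8-fold higher number from compound 1 to compound 4 (0.45 log units; beyond the scatter). Chloro and methoxy therefore each go with a lower number than hydrogen on this carbon, which the unreadable step between compound 1 and compound 3 could not show. From the compounds shown here alone, the full size of both new steps stays open, and chloro and methoxy stay unranked against each other, because both sit at the limit: the limit of < 7 uL/min in this assay, at which 2 of the 4 values shown sit. Going by these compounds, whether an amine or a carboxylic acid at this place would behave like chloro and methoxy also stays open.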